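A few compounds are considered here, and "the series" means these few. Any claim that something is new, unique, unknown or untested is made for them only; others in the source may bear on it.

Measured compounds in the series:
Compound 1 `COc1ccc(-c2cnc(NC(=O)c3ncc[nH]3)n2C)cc1` — > 100000 nM (a limit of the assay, not a number).
Compound 2 `CCCC(=O)Nc1ncc(-c2ccc(OC)cc2)n1C` — > 100000 nM (a limit of the assay, not a number).
Compound 3 `COc1ccc(-c2cnc(NC(=O)c3cccc(C)c3)n2C)cc1` — > 100000 nM (a limit of the assay, not a number).

In a toxicity assay on THP-1 cells (Homo sapiens) for inhibition (on this read-out higher numbers stand for lower toxicity in this test and lower numbers for higher toxicity in this test), none of the three gives a number. Compound 3 stands at > 100000 nM, which is a limit of the assay. The same holds for the two others, so all three steps among them, a step that the two limits leave unreadable from compound 1 to compound 2, a step that the two limits leave unreadable from compound 1 to compound 3 and a step that the two limits leave unreadable from compound 2 to compound 3, cannot be sized; the common point is the limit of > 100000 nM in this assay, at which 3 of the 3 values shown sit.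

Compound 4 `COc1ccc(-c2cnc(NC(=O)c3cccc(Br)c3)n2C)cc1` is not yet measured in this assay. It differs from compound 3 by bromo in place of methyl on an aromatic carbon. Within the data shown here, the only step that touches the same part of the molecule is the one from compound 2 to compound 3, which swaps the whole group on the carbonyl carbon, and it is unreadable; the change now considered is smaller, bromo in place of methyl on an aromatic carbon, meta to a large group.

Nothing in the measured steps gives a readable size, so no step beyond the scatter is expected in this assay; the estimated step is a number no higher from compound 3 to compound 4 (the limit leaves the size open). Compound 4 is expected to sit at the limit again, with an estimate of 100000 nM and a range from 40000 nM to 300000 nM.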

Compound 4, half-maximal cytotoxic concentration: > 100000 nM
Compound 4: only a limit was reported; the forecaster's own chance of this, stated with the estimate: 85%; the middle value sits exactly at the limit.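

In this assay compound 4 gives > 100000 nM as a limit of the assay, not a number, and its steps from compound 1, compound 2 and compound 3 cannot be read. The four compounds share one point: the limit of > 100000 nM in this assay, at which 4 of the 4 values shown sit. The compounds shown leave open whether any structural change here alters toxicity in this test, and by how much.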